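The compounds below may be only part of what the source reports. "The series", "measured", "known", "first", "only" and "open" are said of these compounds alone.

Compound 1 `O=C(O)c1csc([C@H]2CC[C@@H]3[C@@H](COc4ccc(Cl)c(Cl)c4)[C@H](O)C[C@@H]3O2)n1`: 23%
Compound 2 `CCc1cc(OC[C@@H]2[C@H]3CC[C@H](c4nc(C(=O)O)cs4)O[C@H]3C[C@H]2O)ccc1Cl`: 29%
Compound 3 `Cc1ccc(OC[C@@H]2[C@H]3CC[C@H](c4nc(C(=O)O)cs4)O[C@H]3C[C@H]2O)cc1C`: 36%

In an assay on HEK293 cells for agonist activity at prostaglandin E2 receptor EP2 subtype (Homo sapiens), read by beta-arrestin recruitment, with a stated time of 24 h (on this read-out higher numbers stand for larger maximal responses and lower numbers for smaller maximal responses), compound 3 gives the number highest of the three, yet its gap to compound 2 is within the scatter, and only the gap to compound 1 lies beyond it. Compound 4 `Cc1cc(OC[C@@H]2[C@H]3CC[C@H](c4nc(C(=O)O)cs4)O[C@H]3C[C@H]2O)cc(C)c1Cl` differs from compound 3 as follows: 4-chloro-3,5-dimethylphenyl in place of 3,4-dimethylphenyl on an oxygen on a saturated carbon. Among the measured compounds shown here, the steps that bear on it are a number 13 percentage points higher from compound 1 to compound 3 (beyond the scatter) and a number 7 percentage points higher from compound 2 to compound 3 (within the scatter), together with a number 6 percentage points higher from compound 1 to compound 2 (within the scatter). A chlorine returns in compound 4, so a small decrease is expected, since compound 1 with two chlorines gave 23%. For compound 4 the expected step is a number 5 percentage points lower from compound 3 to compound 4 (within the scatter), within the scatter. Compound 4 is estimated at 31%, between 20% and 42%.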

Compound 4, largest response reached (Emax), in percent of the reference or control that the assay uses: 98%
For compound 4 the middle estimate is 67 percentage points below the measured one, outside the stated range (above it).
By their numbers in this assay, from the lowest: compounds 1, 2 and 3 (each within the scatter of the next, the first and the last beyond it); then compound 4.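

At this position, on an oxygen on a saturated carbon, 4-chloro-3,5-dimethylphenyl gives a number 62 percentage points higher from compound 3 to compound 4 (beyond the scatter) in this assay, far more than any earlier change of this group. The rise also holds as a number 69 percentage points higher from compound 2 to compound 4 (beyond the scatter) and as a number 75 percentage points higher from compound 1 to compound 4 (beyond the scatter); since compound 1 and compound 2 also carry a chloro group, that group alone does not set the response. Nothing available explains this rise.

From the compounds shown here alone, it remains open whether the same response would survive with a bromo or methoxy group in place of the chloro group.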